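Replacing cyclohexyl with an amide on a weak series

The source may hold more compounds than are shown below. What is called first, only, known or untested is meant among the compounds shown, and "the series" means these compounds.

Going by the values given here, compound 1 `COc1ccc(C(=O)/C(=C/c2ccc(Cl)cc2Cl)CCOC(C)=O)cc1` is the one member of this small group that returns a number in a functional assay on MCF7 cells (Homo sapiens) for inhibition, read by XTT assay, with a stated time of 48 h (a higher number here means a weaker inhibitor, a lower number a stronger inhibitor), where compound 1 gives 83400 nM. Compound 2 `COc1ccc(C(=O)/C(=C/c2ccc(Cl)cc2Cl)CC(C)C)cc1` does not: in this assay compound 2 gives > 100000 nM, which is a limit of the assay rather than a number. Compound 3 `COc1ccc(C(=O)/C(=C/c2ccc(Cl)cc2Cl)CC2CCCCC2)cc1` stands at the same edge, since in this assay compound 3 gives > 100000 nM, again a limit and not a number. From the compounds shown here alone, because of the limit of > 100000 nM in this assay, at which 2 of the 3 values shown sit, compound 3 can only be placed as a weak inhibitor whose true value is unknown.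

The measured steps say little. Going an at least 1.1-fold higher number from compound 1 to compound 2 (0.07 log units; that floor lies within the scatter), and going an at least 1.1-fold higher number from compound 1 to compound 3 (0.07 log units; that floor lies within the scatter), while the comparison a step that the two limits leave unreadable from compound 2 to compound 3.

Compound 4 `COc1ccc(C(=O)/C(=C/c2ccc(Cl)cc2Cl)CN(C)C(=O)c2ccccc2)cc1` carries benzoyl(methyl)amino in place of cyclohexyl on a saturated chain carbon bound to a double-bonded chain carbon. Among the compounds with values here, no measured step shows that any group at this position moves the read-out beyond the scatter, and two of the three values are limits, so compound 4 is expected to move a number no higher from compound 3 to compound 4 (the limit leaves the size open), that is, not beyond the scatter. Compound 4 is therefore estimated at 100000 nM, with a likely range from 40000 nM to 300000 nM, and it may well land as a limit once more.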

Compound 4, half-maximal inhibitory concentration: > 100000 nM
Compound 4: a limit, no number; the forecaster's own chance of this, stated with the estimate: 60%; the middle value lies on the limit itself.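

The new compound widens the range of groups tested on a saturated chain carbon bound to a double-bonded chain carbon: benzoyl(methyl)amino brings an aromatic ring and a hydrogen-bond acceptor, yet in this assay compound 4 still gives only a limit, > 100000 nM, and not a number. Going by these compounds alone, the one readable step is an at least 1.1-fold higher number from compound 1 to compound 4 (0.07 log units; that floor lies within the scatter), so the result shows no change beyond the scatter, and compound 1 remains the only compound here with a measured number. The steps linking compound 4 to compound 2 and compound 3 cannot be read, and these three compounds cannot be told apart because of this edge of the assay: the limit of > 100000 nM in this assay, at which 3 of the 4 values shown sit.

The compounds shown leave open whether a carboxylic acid, an amine or a hydroxyl group at this place would give a number in this assay, and how that number would stand against compound 1. From the compounds shown here alone, the true values of compound 2, compound 3 and compound 4 also remain unknown, so the order of the isopropyl, cyclohexyl and benzoyl(methyl)amino groups stays unsettled.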